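Swapping Bromine for Chlorine on a Shared Core

The source may report more compounds than this note shows. Statements on the series, on what has been measured and on what is new or still open speak of the compounds shown alone.

compound 1 `CC(=O)N1N=C(c2ccco2)CC1c1ccc([N+](=O)[O-])cc1`: 23000 nM
compound 2 `CC(=O)N1N=C(c2ccco2)CC1c1ccc(Br)cc1`: 18900 nM

In a functional assay on OVCAR cells (Homo sapiens) for cytotoxicity, read by sulforhodamine B assay, with a stated time of 48 h (a lower number here means a stronger inhibitor, a higher number a weaker inhibitor), compound 1 gives 23000 nM, and compound 2 gives 18900 nM. Compound 2 holds the lowest of the two numbers, but the step of a 1.2-fold lower number from compound 1 to compound 2 (0.09 log units; within the scatter) is within the scatter, so the two compounds cannot be told apart on these data. Compound 3 `CC(=O)N1N=C(c2ccco2)CC1c1ccc(Cl)cc1` differs from compound 2 by chloro in place of bromo on an aromatic carbon of a six-membered aromatic ring of carbon only, para to a large group. Going by the values given here, the only measured step that bears on this position is the one from compound 1 to compound 2, where a larger swap of groups at the same place moved the number by a 1.2-fold lower number from compound 1 to compound 2 (0.09 log units; within the scatter). Replacing one halogen by another at that place is a smaller change still, so no step beyond the scatter is expected in this assay. The expected step of a 1.1-fold higher number from compound 2 to compound 3 (0.02 log units; within the scatter) is therefore essentially flat. Compound 3 is estimated at 20000 nM, with a range from 9000 nM to 45000 nM.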

Compound 3, half-maximal inhibitory concentration: 31300 nM
For compound 3 the middle estimate is 1.6-fold (0.19 log units) below the measured one; measured number inside the range.
By their numbers in this assay, from the lowest: compounds 2, 1 and 3 (each within the scatter of the next).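

In this assay, trading bromo for chloro gives a 1.7-fold higher number from compound 2 to compound 3 (0.22 log units; within the scatter) and trading nitro for chloro gives a 1.4-fold higher number from compound 1 to compound 3 (0.13 log units; within the scatter) on the same aromatic carbon. With the earlier step, every pair among the nitro, bromo and chloro compounds now lies within the scatter, so this assay cannot separate these three groups at this place, and the third compound adds no order among them. No supporting measurement bears on these numbers.

Going by these compounds, an amine, a carboxylic acid or a longer chain at this place would be a different kind of group from these three, and whether any such group moves the number beyond the scatter stays open. On these data alone, the shared core stays the same throughout, so the effect of changes elsewhere on it also stays open.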